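The source may hold more compounds than are shown below. What is called first, only, known or untested is meant among the compounds shown, and "the series" means these compounds.

Three measured compounds share a toluenesulfonamide attached to the same bicyclic core. Compound 1 `Cc1ccc(S(=O)(=O)Nc2cccc3[nH]nc(Br)c23)cc1` gives 53900 nM in a functional assay on P388 cells (Mus musculus) for cytotoxicity, read by MTT assay, with a stated time of 72 h; on this read-out higher numbers stand for weaker inhibition and lower numbers for stronger inhibition. Compound 2 `CCOc1ccc(NS(=O)(=O)c2ccc(C)cc2)c2cn[nH]c12`, which carries an ethoxy group but no bromo, gives 43500 nM in this assay and stands second highest of the three numbers, within the scatter of compound 1 and well above compound 3. Compound 3 `CCOc1ccc(NS(=O)(=O)c2ccc(C)cc2)c2c(Br)n[nH]c12`, with both ethoxy and bromo, gives 5210 nM in this assay. The two measured steps are a 10-fold lower number from compound 1 to compound 3 (1.01 log units; beyond the scatter) and an 8.3-fold lower number from compound 2 to compound 3 (0.92 log units; beyond the scatter).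

Compound 4 `C=CCn1ncc2c(NS(=O)(=O)c3ccc(C)cc3)ccc(OCC)c21` has not yet been measured. It differs from compound 2 by allyl in place of hydrogen on an aromatic nitrogen. Neither measured step bears on this change: one concerns an ethoxy group on an aromatic carbon, the other a bromo group on an aromatic carbon, and the aromatic nitrogen carries hydrogen in all three measured compounds. Going by the values given here, the data give no step that anchors an expectation for substitution at this nitrogen. With nothing to point either way, the step from compound 2 to compound 4 in this assay is expected to stay within the scatter, as a 1.1-fold lower number from compound 2 to compound 4 (0.04 log units; within the scatter). Compound 4 is therefore estimated at about 40000 nM in this assay, with a range from 12000 nM to 130000 nM.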

Compound 4, half-maximal inhibitory concentration: 51800 nM
Compound 4: the middle estimate sits 1.3-fold (0.11 log units) below what was measured, and the stated range covers the measured number.
By their numbers in this assay, from the lowest: compound 3; then compounds 2, 4 and 1 (each within the scatter of the next).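

Allyl in place of hydrogen on the aromatic nitrogen gives a 1.2-fold higher number from compound 2 to compound 4 (0.08 log units; within the scatter) in this assay, so this nitrogen, which carries hydrogen in all the earlier compounds, can bear an allyl group with no change that stands out from the scatter. On compound 2, this change therefore differs from bromo in place of hydrogen on an aromatic carbon, which gives an 8.3-fold lower number from compound 2 to compound 3 (0.92 log units; beyond the scatter) and lies beyond the scatter. No evidence is available to account for the allyl result.

As far as these compounds go, it remains open whether other groups on this nitrogen, such as methyl, benzyl, a longer chain or a chain ending in an amine or a carboxylic acid, would also leave the number within the scatter of compound 2. From the compounds shown here alone, it is also open whether allyl on this nitrogen would have as little effect on compound 3, where bromo is present and the number is already lower, so the step seen here on compound 2 cannot yet be extended to that compound.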